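The compounds below may be only part of what the source reports. "The series", "measured", "known", "first", "only" and "open" are said of these compounds alone.

Within the data shown here, compound 2 `COc1cc(-c2nn(-c3cccc(NC(=O)c4ccc(Cl)c(C(F)(F)F)c4)c3)cc2-c2ccncc2)ccc1Cl` gives the highest number among the three compounds measured so far in a functional assay on BT-549 cells (Homo sapiens) for inhibition, read by sulforhodamine B assay, with a stated time of 48 h (a higher number here means a weaker inhibitor of growth, a lower number a stronger inhibitor of growth), with 7540 nM. The two ureas built on a related core, compound 1 `O=C(Nc1cccc(-n2cc(-c3ccncc3)c(-c3ccc(Cl)c(O)c3)n2)c1)Nc1ccc(Cl)c(Cl)c1` with 1700 nM and compound 3 `O=C(Nc1cccc(-n2cc(-c3ccncc3)c(-c3ccc(Cl)c(O)c3)n2)c1)Nc1cc(C(F)(F)F)cc(C(F)(F)F)c1` with 1090 nM, both lie well beyond the scatter from compound 2. Compound 4 `COc1cc(-c2nn(-c3cccc(NC(=O)Nc4cccc(C(F)(F)F)c4)c3)cc2-c2ccncc2)ccc1Cl` keeps the core of compound 2 and changes one place: (3-(trifluoromethyl)phenyl)amino in place of 4-chloro-3-(trifluoromethyl)phenyl on a carbonyl carbon. This turns the amide of compound 2 into a urea of the kind found in compounds 1 and 3. Because compound 1 sits at 1700 nM and compound 3 at 1090 nM, a step toward stronger growth inhibition is expected, beyond the scatter, as the estimated step of a 3.0-fold lower number from compound 2 to compound 4 (0.48 log units; beyond the scatter). For compound 4 the expected result in this assay is 2500 nM, within the range 900 nM to 7000 nM.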

Compound 4, concentration for 50% growth inhibition: 1250 nM
Compound 4: the middle estimate sits 2.0-fold (0.30 log units) above what was measured; measured number inside the range.
By their numbers in this assay, from the lowest: compounds 3, 4 and 1 (each within the scatter of the next); then compound 2.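

Among these compounds, with the core held fixed, which no earlier pair allowed, this assay proves sensitive to what sits on this carbonyl carbon: (3-(trifluoromethyl)phenyl)amino in place of 4-chloro-3-(trifluoromethyl)phenyl gives a 6.0-fold lower number from compound 2 to compound 4 (0.78 log units; beyond the scatter). This single swap both adds a nitrogen carrying a hydrogen-bond donor and removes a chlorine. Nothing measured here explains the step.

Whether the added nitrogen or the lost chlorine accounts for the step stays open. Also open, from the compounds shown here alone, is how an amine or a carboxylic acid on that aromatic ring would behave.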